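A Methyl Group Relocated Within the Same Ring

A few compounds are considered here, and "the series" means these few. Any claim that something is new, unique, unknown or untested is made for them only; others in the source may bear on it.

Compound 1 `Cc1nn(C2COC2)cc1Nc1nc(N)c2c(C#N)c(N3CCC[C@H]3C)n(C)c2n1` gives 38 nM in an assay on isolated protein for inhibition of Leucine-rich repeat serine/threonine-protein kinase 2 (Homo sapiens), read by TR-FRET and LanthaScreen, with stated times of 50 min and 30 min, in the presence of a further agent that is not named here (on this read-out lower numbers stand for stronger inhibition and higher numbers for weaker inhibition), the lowest of the two numbers seen. Compound 2 `Cc1nn(CC(C)(C)O)cc1Nc1nc(N)c2c(C#N)c(N3CCC[C@H]3C)n(C)c2n1` gives 49 nM; the step of a 1.3-fold higher number from compound 1 to compound 2 (0.11 log units; within the scatter) shows that exchanging the group on an aromatic nitrogen barely matters. Compound 3 `Cc1c(Nc2nc(N)c3c(C#N)c(N4CCC[C@H]4C)n(C)c3n2)cnn1C1COC1` differs from compound 1 by 5-methyl-1-(oxetan-3-yl)-1H-pyrazol-4-yl in place of 3-methyl-1-(oxetan-3-yl)-1H-pyrazol-4-yl on a nitrogen on an aromatic ring. Going by the values given here, no measured step bears directly on this rearrangement, since the only step measured alters a different part of the same ring. Compound 3 is therefore expected to give 60 nM, between 20 nM and 200 nM, a step of a 1.6-fold higher number from compound 1 to compound 3 (0.20 log units; within the scatter) that would not exceed the scatter.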

Compound 3, half-maximal inhibitory concentration: 47 nM
The estimate for compound 3 lay 1.3-fold (0.11 log units) above the measured number; measured number inside the range.
By their numbers in this assay, from the lowest: compounds 1, 3 and 2 (each within the scatter of the next).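

Relocating the methyl group within the ring gives a 1.2-fold higher number from compound 1 to compound 3 (0.09 log units; within the scatter) and so stays within the scatter. The earlier step changed only the group on the aromatic nitrogen, whereas this one shows that 5-methyl-1-(oxetan-3-yl)-1H-pyrazol-4-yl and 3-methyl-1-(oxetan-3-yl)-1H-pyrazol-4-yl cannot be told apart on this read-out. No supporting data here explain this result.

Still open, on these data alone, is whether the ring needs its methyl group at all. Nor do these compounds show whether an ethyl group or a chlorine atom in its place would move the number beyond the scatter.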